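From phenyl to pyridin-2-yl on a shared core

The source may report more compounds than this note shows. Statements on the series, on what has been measured and on what is new or still open speak of the compounds shown alone.

- compound 1 `CC(C)(C)c1nc(C2CCCC2)c2c(N)c(C#N)c(N)nc2n1` gives < 1000 nM as a limit
- compound 2 `CC(C)(C)c1nc(-c2ccccc2)c2c(N)c(C#N)c(N)nc2n1` gives 4000 nM as a number

Going by the values given here, in a physicochemical assay for solubility, in phosphate buffer, with a stated time of 18 h (on this read-out lower numbers stand for lower solubility and higher numbers for higher solubility), compound 2 gives 4000 nM as the only true number so far. Compound 1 gives < 1000 nM in this assay and that is a limit of the assay, not a number.

The move to compound 3 `CC(C)(C)c1nc(-c2ccccn2)c2c(N)c(C#N)c(N)nc2n1` is pyridin-2-yl in place of phenyl on an aromatic carbon and puts pyridin-2-yl in place of phenyl on an aromatic carbon. Among the compounds with values here, one measured step bears on this place, an at least 4.0-fold higher number from compound 1 to compound 2 (0.60 log units; beyond the scatter) when phenyl replaced cyclopentyl. That step rests on a limit of < 1000 nM in this assay, at which 1 of the 2 values shown sits, and involves a different swap, so it sets no size for this one. A slight rise is expected, but no step beyond the scatter, and the estimated move is a 1.5-fold higher number from compound 2 to compound 3 (0.18 log units; within the scatter) in this assay for this pair. Compound 3 is expected to read 6000 nM in this estimate (range 2000 nM to 18000 nM).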

Compound 3, solubility: 87000 nM
Compound 3: the middle estimate sits 15-fold (1.16 log units) below what was measured; measured number outside the range, above it.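

In this assay, a 22-fold higher number from compound 2 to compound 3 (1.34 log units; beyond the scatter), although phenyl and pyridin-2-yl have the same count of heavy atoms and differ by one ring nitrogen in place of a carbon. This place on the shared core is therefore far more sensitive to a single ring atom than compounds 1 and 2 could show. The wider step is also large, an at least 87-fold higher number from compound 1 to compound 3 (1.93 log units; beyond the scatter), but its full size stays unknown, since compound 1 is known only through a limit of the assay: the limit of < 1000 nM in this assay, at which 1 of the 3 values shown sits.

The compounds shown hold a ring nitrogen in only one arrangement, that of pyridin-2-yl, so they cannot separate the presence of that nitrogen from its location, and they do not explain the rise. As far as these compounds go, how an amine or a carboxylic acid on this same aromatic carbon would read also remains open.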